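The source may hold more compounds than are shown below. What is called first, only, known or untested is meant among the compounds shown, and "the series" means these compounds.

Among the measured compounds shown here, compound 2 `CN1C(=O)C(c2cccc(C(F)(F)F)c2)N(C)c2nc(Nc3ccc(S(N)(=O)=O)cc3)ncc21` gives 2710 nM in an assay on Sf9 cells for inhibition of serine/threonine-protein kinase 4 (Homo sapiens), read by luminescence and ADP-Glo, with a stated time of 1 h, in the presence of a further agent that is not named here (on this read-out lower numbers stand for stronger inhibition and higher numbers for weaker inhibition), the highest of the two numbers so far. For the measured compounds named here, its nearest neighbour is compound 1 `CN1C(=O)C(c2cccc(F)c2)N(C)c2nc(Nc3ccc(S(N)(=O)=O)cc3)ncc21`, which gives 134 nM in this assay; the only measured step, a 20-fold higher number from compound 1 to compound 2 (1.31 log units; beyond the scatter), lies beyond the scatter and is large.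

Compound 3 `CN1C(=O)C(c2ccccc2F)N(C)c2nc(Nc3ccc(S(N)(=O)=O)cc3)ncc21` is not yet measured. It differs from compound 2 in one place: 2-fluorophenyl in place of 3-(trifluoromethyl)phenyl on a saturated ring carbon. The change undoes the trifluoromethyl of compound 2 and brings back a single fluoro, but as 2-fluorophenyl rather than the fluorophenyl of compound 1, so the measured step does not match it exactly. The step from compound 1 to compound 2 is the one that bears on it: a large rise on going from fluoro to trifluoromethyl on an aromatic carbon. Removing the trifluoromethyl is therefore expected to lower the number in this assay by a sizeable step, though the new fluoro placement leaves the size uncertain; compound 3 is expected to show an 11-fold lower number from compound 2 to compound 3 (1.04 log units; beyond the scatter). The estimate for compound 3 is 250 nM, with a range from 60 nM to 1000 nM.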

Compound 3, half-maximal inhibitory concentration: 75 nM
Beside the measured number, compound 3's estimate is 3.3-fold (0.52 log units) above it; low and high end bracket the measured number.
By their numbers in this assay, from the lowest: compounds 3 and 1 (each within the scatter of the next); then compound 2.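

In this assay, moving the single fluoro on the phenyl gives a 1.8-fold lower number from compound 1 to compound 3 (0.25 log units; within the scatter), so 2-fluorophenyl and 3-fluorophenyl on the saturated ring carbon cannot be told apart here, and this position accepts a single fluoro at either of these two placements. Replacing 3-(trifluoromethyl)phenyl with 2-fluorophenyl gives a 36-fold lower number from compound 2 to compound 3 (1.56 log units; beyond the scatter), which leaves compound 2 the weakest of the three and shows that the high number does not extend to both fluorophenyl compounds. Nothing available gives a reason for either step.

On these data alone, whether the high number of compound 2 goes with trifluoromethyl as such or with its placement on the phenyl stays open, as these compounds carry that group at one placement only. Also open, as far as these compounds go, is how this position reads with an unsubstituted phenyl, with a chloro or methoxy on the phenyl, or with a phenyl carrying an amine or a carboxylic acid.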